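The compounds below may be only part of what the source reports. "The series", "measured", "known", "first", "only" and "open" are said of these compounds alone.

Measured in a functional assay on C6 cells (Rattus norvegicus) for cytotoxicity, read by MTT assay, with a stated time of 24 h, tested at 50 ug/mL (a higher number here means a weaker effect of the compound at the concentration tested, a lower number a stronger effect), so far:
compound 1 `Cc1ccc(-c2cs/c(=N/NC(=O)CSc3nnnn3C)n2-c2ccccc2)cc1` gives 44.3%
compound 2 `Cn1cnnc1SCC(=O)N/N=c1/scc(-c2ccc(C#N)cc2)n1-c1ccccc1` gives 58.8%

Compound 2 shows the highest number of the two in this assay; its nearest neighbour is compound 1, whose value lies lower by a gap beyond the usual scatter, so compound 2 is the weaker of the pair at the concentration tested.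

Compound 3 `Cn1nnnc1SCC(=O)N/N=c1/scc(-c2ccc(C#N)cc2)n1-c1ccccc1` has not been measured. It differs from compound 2 in one place: 1-methyl-1H-tetrazol-5-yl in place of 4-methyl-4H-1,2,4-triazol-3-yl on a sulfur. For the measured compounds named here, no step between measured compounds covers a change of this kind, so the direction of the step cannot be read from the series. The exchange keeps the same count of heavy atoms and the same arrangement of a methylated five-membered aromatic ring on the sulfur, and a step within the usual scatter is expected. Compound 3 is therefore estimated at 57%, with a range from 42% to 74%; the step of a number 1.8 percentage points lower from compound 2 to compound 3 (within the scatter) that this estimate implies is expected to be small.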

Compound 3, a percentage reported as activity, at one concentration (the size of the read-out at that concentration, not a potency): 35.6%
Compound 3: middle estimate off by 21.4 percentage points, on the high side; the measured number lies below the stated range.
By their numbers in this assay, from the lowest: compounds 3 and 1 (each within the scatter of the next); then compound 2.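

In this assay the ring on the sulfur is not an interchangeable part: 1-methyl-1H-tetrazol-5-yl in place of 4-methyl-4H-1,2,4-triazol-3-yl gives a number 23.2 percentage points lower from compound 2 to compound 3 (beyond the scatter) with the count of heavy atoms unchanged. With the 1-methyl-1H-tetrazol-5-yl group held, cyano in place of methyl on an aromatic carbon gives a number 8.7 percentage points lower from compound 1 to compound 3 (within the scatter) and so shows no separable difference between those two groups in this pair. No measurement shown here explains the step on the sulfur.

On these data alone, whether that step recurs with methyl rather than cyano on the aromatic carbon remains open. Also open, as far as these compounds go, is how a 1-phenyl-1H-tetrazol-5-yl group or a carboxylic acid in place of the methylated ring on the same sulfur would read in this assay.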